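From dimethylphenyl to pyrrolyl in the series

The source may report more compounds than this note shows. Statements on the series, on what has been measured and on what is new or still open speak of the compounds shown alone.

In a functional assay on DU-145 cells (Homo sapiens) for inhibition, read by trypan blue exclusion, with a stated time of 96 h (a higher number here means a weaker inhibitor of growth, a lower number a stronger inhibitor of growth), compound 1 (`Cc1ccc(C)c(/C=C(/SCc2ccc(Cl)cc2)C(=O)c2ccc(Cl)cc2)c1`) gives 10000 nM as its reading. Compound 2 (`Cc1cc(C)cc(/C=C(/SCc2ccc(Cl)cc2)C(=O)c2ccc(Cl)cc2)c1`) gives 10000 nM on the same read-out, level with compound 1. Among the measured compounds shown here, the only measured step is no change at the digits printed from compound 1 to compound 2 (within the scatter) and exchanges 2,5-dimethylphenyl for 3,5-dimethylphenyl.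

Compound 3 (`O=C(/C(=C\c1ccc[nH]1)SCc1ccc(Cl)cc1)c1ccc(Cl)cc1`) carries a different ring at that place: 1H-pyrrol-2-yl in place of 3,5-dimethylphenyl on a double-bonded chain carbon bound to a double-bonded chain carbon describes 1H-pyrrol-2-yl in place of 3,5-dimethylphenyl on a double-bonded chain carbon bound to a double-bonded chain carbon. The measured step bears only loosely on this change, as it compares two dimethylphenyl groups. For the measured compounds named here, no measured compound shows what a different ring type does here, so the absence of movement between compound 1 and compound 2 cannot simply be carried over.

A modest move towards stronger growth inhibition is expected, with a result level with compound 2 still quite possible. The estimated size of the change is a 2.0-fold lower number from compound 2 to compound 3 (0.30 log units; within the scatter) in this assay. Compound 3 is estimated at 5000 nM in this assay with an expected range from 1000 nM to 12000 nM overall.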

Compound 3, concentration for 50% growth inhibition: 10000 nM
Estimate against measurement, compound 3: 2.0-fold (0.30 log units) below, within the range that was stated.
By their numbers in this assay, from the lowest: compounds 1, 2 and 3 (each within the scatter of the next).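

In this assay the replacement of the dimethylphenyl group by 1H-pyrrol-2-yl on a double-bonded chain carbon bound to a double-bonded chain carbon reads (no change at the digits printed from compound 2 to compound 3 (within the scatter)) and, against the other dimethylphenyl isomer, (no change at the digits printed from compound 1 to compound 3 (within the scatter)). The earlier pair compared only two arrangements of the same substituted ring, whereas this result extends the level readings to a ring of a different type, a five-membered aromatic ring with one nitrogen and one hydrogen-bond donor, so that neither the ring type nor the two methyl groups separate these three compounds in this read-out. No evidence accompanies this result that could account for the level readings.

All three compounds carry an aromatic ring at this place and give the same reading, so the shown data do not tell whether any replacement here can move the number, for example a ring bearing a carboxylic acid, a dimethylamino group or a longer alkyl chain. The contribution of the rest of the shared core also remains open, since every compound shown keeps it unchanged.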